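A few compounds are considered here, and "the series" means these few. Any claim that something is new, unique, unknown or untested is made for them only; others in the source may bear on it.

Measured compounds:
compound 1 `CC(=O)c1cc(-c2ccc(F)cc2)cc2cc(-c3ccc(F)cc3)[nH]c12` — 13800 nM
compound 2 `COc1ccc(-c2cc3cc(-c4ccccc4)cc(C(C)=O)c3[nH]2)cc1` — 18900 nM

Among the measured compounds shown here, in a functional assay on HeLa cells (Homo sapiens) for cytotoxicity, read by MTT assay, with a stated time of 2 days (a lower number here means that less compound is tolerated, a higher number that more compound is tolerated), compound 2 gives 18900 nM, the upper one of the two numbers so far, while in this assay compound 1 gives 13800 nM, a value within the scatter of it; the pair supports no ordering. Compound 3 `COc1ccc(-c2cc3cc(-c4ccc(F)cc4)cc(C(C)=O)c3[nH]2)cc1` is still to be measured. It differs from compound 2 by fluoro in place of hydrogen on an aromatic carbon, in words fluoro in place of hydrogen on an aromatic carbon. For the measured compounds named here, no measured step of this kind exists, so no direction beyond the scatter is expected: a 1.2-fold lower number from compound 2 to compound 3 (0.07 log units; within the scatter) is the estimated step. For compound 3 the expected value in this assay is 16000 nM, in the range 8000 nM to 32000 nM.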

Compound 3, concentration lethal to 50% of the cells: 42800 nM
The estimate for compound 3 lay 2.7-fold (0.43 log units) below the measured number; measured number outside the range, above it.
By their numbers in this assay, from the lowest: compounds 1 and 2 (each within the scatter of the next); then compound 3.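

In this assay, among the compounds shown here, phenyl to 4-fluorophenyl, with the fluoro para to a large group, gives a 2.3-fold higher number from compound 2 to compound 3 (0.35 log units; beyond the scatter), the first step beyond the scatter. Methoxy in place of fluoro on an aromatic carbon gives a 3.1-fold higher number from compound 1 to compound 3 (0.49 log units; beyond the scatter), so compound 3, which carries both groups, stands apart from compounds 1 and 2, whose numbers lie within the scatter of each other. Nothing shown accounts for either step. Open, on these data alone, is how an amine or a carboxylic acid in place of the fluoro would read in this assay. Also open, as far as these compounds go, is whether chloro would give a step of the same direction.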